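The compounds below may be only part of what the source reports. "The series", "measured", "known", "first", "only" and "open" are said of these compounds alone.

Measured in an ADME assay on Vero cells (Chlorocebus sabaeus) for cytotoxicity, read by MTT assay, with a stated time of 72 h; on this read-out lower numbers stand for higher toxicity in this test and higher numbers for lower toxicity in this test:
- Compound 1 `CCO/N=C(\C)CN1CCN(c2c(F)cc3c(=O)c(C(=O)O)cn(C4CC4)c3c2OC)CC1C` gives 31.3 ug/mL
- Compound 2 `COc1c(N2CCN(C/C(C)=N/NC(N)=O)C(C)C2)c(F)cc2c(=O)c(C(=O)O)cn(C3CC3)c12` gives 500 ug/mL

Going by the values given here, compound 2, at 500 ug/mL, holds the higher of the two numbers, and compound 1 is its only neighbour. Compound 3 `CO/N=C(\C)CCN1CCN(c2c(F)cc3c(=O)c(C(=O)O)cn(C4CC4)c3c2OC)CC1C` comes from compound 2 by this change: a group of 6 heavy atoms (4 carbon, 1 nitrogen, 1 oxygen; no ring) in place of a group of 7 heavy atoms (3 carbon, 3 nitrogen, 1 oxygen; no ring), on a saturated chain carbon bound to an amine nitrogen in a ring. Among the compounds with values here, one measured step bears on it: a 16-fold higher number from compound 1 to compound 2 (1.20 log units; beyond the scatter), a large step beyond the scatter, with ureido in place of ethoxy on a double-bonded nitrogen. Compound 3 has no ureido, and neither does compound 1 at 31.3 ug/mL, so most of that step is expected to reverse, giving a lower number in this assay. Within the data shown here, no measured pair tests this exact change, so the range stays wide. The expected step is a 13-fold lower number from compound 2 to compound 3 (1.10 log units; beyond the scatter). For compound 3 the estimated value is 40 ug/mL, with an expected range from 12 ug/mL to 130 ug/mL.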

Compound 3, half-maximal cytotoxic concentration: 157 ug/mL
Compound 3: middle estimate off by 3.9-fold (0.59 log units), on the low side, outside the stated range (above it).
By their numbers in this assay, from the lowest: compound 1; then compound 3; then compound 2.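

On this saturated chain carbon bound to an amine nitrogen in a ring, this assay separates two groups with the same heavy-atom composition and no ring, with a 5.0-fold higher number from compound 1 to compound 3 (0.70 log units; beyond the scatter), so that composition alone does not fix the number. Removing the group that carries the ureido also does not bring the number down to that of compound 1: the change is a 3.2-fold lower number from compound 2 to compound 3 (0.50 log units; beyond the scatter), and compound 2 remains the highest of the three. No measured evidence is available here to explain either step.

The compounds shown leave open how a longer chain ending in an amine or a carboxylic acid would read at this position. They also leave open whether a thiourea in place of the ureido would keep the number of compound 2.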